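Agonist series: an aryl group in place of cyclobutyl

The compounds below may be only part of what the source reports. "The series", "measured", "known", "first", "only" and "open" are said of these compounds alone.

Measured so far:
compound 1 `O=C(O)c1ccccc1-c1ccc(CCc2ncc(CC3CCC3)[nH]2)cc1` gives 7.1 nM
compound 2 `CC(C)(C)CCc1cnc(CCc2ccc(-c3ccccc3C(=O)O)cc2)[nH]1` gives 6.2 nM

In an in vitro functional assay on cells for agonist activity at Bombesin receptor subtype-3 (Mus musculus), read by luminescence and calcium flux (a higher number here means that more compound is needed for the effect, a lower number that less compound is needed), compound 1 and compound 2 sit within the scatter of each other; the step of a 1.1-fold lower number from compound 1 to compound 2 (0.06 log units; within the scatter) is a swap of one saturated group for another at the same place. Compound 3 `COc1ccc(Cc2cnc(CCc3ccc(-c4ccccc4C(=O)O)cc3)[nH]2)cc1` carries 4-methoxyphenyl in place of cyclobutyl on a saturated chain carbon bound to an aromatic carbon. Among the compounds with values here, only that one measured step bears on this position, and it was flat, but no measured step covers an aromatic group with a hydrogen-bond acceptor here. A step of a 1.4-fold higher number from compound 1 to compound 3 (0.15 log units; within the scatter) is expected, modest and uncertain in direction. Compound 3 is estimated at 10 nM, range 3 nM to 40 nM.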

Compound 3, half-maximal effective concentration: 513 nM
For compound 3 the middle estimate is 51-fold (1.71 log units) below the measured one; the measured number lies above the stated range.
By their numbers in this assay, from the lowest: compounds 2 and 1 (each within the scatter of the next); then compound 3.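

The position is not indifferent to what sits on the saturated chain carbon. The flat swap between the two saturated groups gave no sign of this, yet 4-methoxyphenyl costs heavily, with (a 72-fold higher number from compound 1 to compound 3 (1.86 log units; beyond the scatter)) and (an 83-fold higher number from compound 2 to compound 3 (1.92 log units; beyond the scatter)). No available evidence accounts for this loss.

The compounds shown do not separate the aromatic ring from its methoxy group as the source of the loss. Unsubstituted phenyl and cyclohexyl at this place would be the direct comparisons, and whether any aromatic group can hold potency here stays open.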